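This account rests on a few compounds, and the source may have more. Where it says the series, first, only, none or still open, it means among the compounds named here.

For the measured compounds named here, in an ADME assay on a cell-free system (serum, Homo sapiens) for metabolic stability, read by HPLC, tested at 2 mM (a lower number here means that the compound disappears faster, a higher number that the compound lasts longer), compound 2 `O=C(O[C@H]1C[C@H](n2cc(F)c(=O)[nH]c2=O)O[C@@H]1COP(=O)([O-])Oc1ccc[n+](Cc2ccccc2)c1)c1ccccc1` gives 14.4 h, the lower of the two numbers so far, while compound 1 `C[n+]1cccc(OP(=O)([O-])OC[C@H]2O[C@@H](n3cc(F)c(=O)[nH]c3=O)C[C@@H]2OC(=O)c2ccccc2)c1` gives 37.3 h. Compound 3 `CCOC(=O)C[n+]1cccc(OP(=O)([O-])OC[C@H]2O[C@@H](n3cc(F)c(=O)[nH]c3=O)C[C@@H]2OC(=O)c2ccccc2)c1` differs from compound 2 by ethoxycarbonyl in place of phenyl on a saturated chain carbon bound to an aromatic nitrogen. Going by the values given here, one measured step bears on this carbon, the modest 2.6-fold lower number from compound 1 to compound 2 (0.41 log units; beyond the scatter), with phenyl in place of hydrogen. Among the compounds with values here, no measured compound carries ethoxycarbonyl, so the direction is uncertain, but a modest step is expected, leaning lower. The estimated change is a 1.4-fold lower number from compound 2 to compound 3 (0.16 log units; within the scatter). For compound 3, the expected half-life is 10 h, with an estimated range of 3.5 h to 28 h.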

Compound 3, half-life in the Homo sapiens assay: 1.4 h
Beside the measured number, compound 3's estimate is 7.1-fold (0.85 log units) above it; measured number outside the range, below it.
By their numbers in the Homo sapiens assay, from the lowest: compound 3; then compound 2; then compound 1.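

At this saturated chain carbon bound to an aromatic nitrogen, the choice of group matters far more than the modest earlier step suggested: in the Homo sapiens assay, ethoxycarbonyl gives a 10-fold lower number from compound 2 to compound 3 (1.01 log units; beyond the scatter), and against plain hydrogen it gives a 27-fold lower number from compound 1 to compound 3 (1.43 log units; beyond the scatter). Both steps are large, so this position tolerates phenyl much better than ethoxycarbonyl. A fall of similar size appears in a physicochemical assay for metabolic stability, read by HPLC, tested at 2 mM (a lower number here means that the compound disappears faster, a higher number that the compound lasts longer), where compound 2 gives 10.8 h and compound 3 gives 1.1 h, so the loss is not peculiar to serum: the measured half-life of compound 2, 10.8 h, and of compound 3, 1.1 h, a 9.8-fold lower number (0.99 log units; beyond the scatter)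

The compounds shown do not tell whether the whole ethoxycarbonyl group is needed for this fall. A carboxylic acid or a dimethylamide on the same carbon remains an open comparison.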